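The source may report more compounds than this note shows. Statements on the series, on what has been measured and on what is new or still open speak of the compounds shown alone.

Compound 1 `COc1cc(N(CC(C)C)c2cccc(C(F)(F)F)c2)cnc1C(=O)[C@H]1C[C@@H]1C(=O)O` and compound 2 `COc1cc(N(CC2CC2)c2cc(Cl)c(F)cc2F)cnc1C(=O)[C@H]1C[C@@H]1C(=O)O` share one core and differ at both the group on the nitrogen and the aryl ring. In an assay on isolated protein for inhibition of leukotriene C4 synthase (Homo sapiens), read by LC-MS, with stated times of 45 min and 20 min (on this read-out higher numbers stand for weaker inhibition and lower numbers for stronger inhibition), compound 1 gives 20.6 nM, and in this assay compound 2 gives 27.6 nM; compound 2 stands at the upper of the two numbers, a gap that lies within the usual scatter. Compound 3 `COc1cc(N(CC(C)C)c2cc(Cl)c(F)cc2F)cnc1C(=O)[C@H]1C[C@@H]1C(=O)O` differs from compound 2 by isopropyl in place of cyclopropyl on a saturated chain carbon bound to a nitrogen on an aromatic ring. Compound 1 carries the same isobutyl group, and nothing here points to a step beyond the scatter. Compound 3 is estimated at 22 nM, with a range from 8 nM to 60 nM. The expected step from compound 2 to compound 3 is a 1.3-fold lower number from compound 2 to compound 3 (0.10 log units; within the scatter).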

Compound 3, half-maximal inhibitory concentration: 8.5 nM
For compound 3 the middle estimate is 2.6-fold (0.41 log units) above the measured one; the measured number falls inside the stated range.
By their numbers in this assay, from the lowest: compound 3; then compounds 1 and 2 (each within the scatter of the next).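

In this assay, with the aryl ring held fixed, cyclopropylmethyl to isobutyl on the nitrogen gives a 3.2-fold lower number from compound 2 to compound 3 (0.51 log units; beyond the scatter), so this position responds to the change even though the earlier pair, differing in two places, could not show it. With isobutyl held fixed, the aryl ring also matters: 5-chloro-2,4-difluorophenyl in place of 3-(trifluoromethyl)phenyl gives a 2.4-fold lower number from compound 1 to compound 3 (0.38 log units; beyond the scatter). Nothing available explains either step.

As far as these compounds go, whether a longer chain or a chain bearing an amine at this position would go further remains open, as does the size of the aryl step with cyclopropylmethyl on the nitrogen.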